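The source may hold more compounds than are shown below. What is called first, only, known or untested is meant among the compounds shown, and "the series" means these compounds.

Compound 3 `COc1cccc(CNCCCNc2ccnc3cc(CC(C)C)ccc23)c1O` is one of three analogues of a shared core examined in a physicochemical assay for acid dissociation. Compound 1 `COc1cccc(CNCCCNc2ccnc3cc(-c4ccc(C(F)(F)F)cc4)ccc23)c1O` gives 9.47, compound 2 `COc1cccc(CNCCCNc2ccnc3cc(Oc4ccc(C(C)(C)C)cc4)ccc23)c1O` gives 9.28, and compound 3 gives 9.47; compound 3 thus stands level with compound 1 at the digits shown, the two together the highest of the three numbers, and the step of a number 0.19 log units higher from compound 2 to compound 3 (within the scatter) stays within the scatter. Compound 4 `COc1cccc(CNCCCNc2ccnc3cc(Cc4cc(C)cc(C)c4)ccc23)c1O` differs from compound 3 by 3,5-dimethylphenyl in place of isopropyl on a saturated chain carbon bound to an aromatic carbon. The earlier exchanges on an aromatic carbon bear on this: no change at the digits printed from compound 1 to compound 3 (within the scatter), a number 0.19 log units lower from compound 1 to compound 2 (within the scatter) and a number 0.19 log units higher from compound 2 to compound 3 (within the scatter) were all within the scatter. Compound 4 is therefore expected to show a number 0.02 log units lower from compound 3 to compound 4 (within the scatter), nothing beyond the scatter. The estimate for compound 4 is 9.45, between 9.2 and 9.7.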

Compound 4, acid dissociation constant: 9.47
Compound 4: the middle estimate sits 0.02 log units below what was measured, and the stated range covers the measured number.
By their numbers in this assay, from the lowest: compounds 2, 1, 3 and 4 (each within the scatter of the next).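

In this assay, the exchange of isopropyl for 3,5-dimethylphenyl on a saturated chain carbon bound to an aromatic carbon adds a six-membered aromatic ring and yet gives no step beyond the scatter (no change at the digits printed from compound 3 to compound 4 (within the scatter)). The wider exchanges read the same way (no change at the digits printed from compound 1 to compound 4 (within the scatter); a number 0.19 log units higher from compound 2 to compound 4 (within the scatter)). Nothing measured here offers an account of this. Still open, on these data alone, is whether an amine or a carboxylic acid on this chain carbon, or a longer chain, would give a step beyond the scatter.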